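This account rests on a few compounds, and the source may have more. Where it says the series, first, only, none or still open, it means among the compounds named here.

Compound 1 `CN(C)CCCc1ccc(C(=O)/C=C/c2ccc(Cl)cc2)cc1` gives 5.92 ug/mL in an ADME assay on Vero cells (Chlorocebus sabaeus) for cytotoxicity, with a stated time of 72 h; on this read-out lower numbers stand for higher toxicity in this test and higher numbers for lower toxicity in this test. Compound 2 `CCCCNc1ccc(C(=O)C2CC2c2ccc(Cl)cc2)cc1` gives 316 ug/mL in this assay. Compound 3 `CCCCCCCC/C=C\CCCCCCCCNc1ccc(C(=O)C2CC2c2ccc(Cl)cc2)cc1` gives 393 ug/mL in this assay.

Among these three numbers compound 2 stands second highest. Its nearest neighbour is compound 3, whose number is higher by a margin that stays within the scatter, so the two cannot be set apart on this read-out. Compound 1 stands furthest from compound 2, with a much lower number, and that gap lies beyond the scatter. Compounds 2 and 3 share the same core and differ only in the chain on the aromatic nitrogen; their closeness shows that this read-out is little moved by that chain over the range covered.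

Compound 4 `O=C(c1ccc(NCCn2cncn2)cc1)C1CC1c1ccc(Cl)cc1` has not been measured. It differs from compound 2 in one place: 1H-1,2,4-triazol-1-yl in place of ethyl on a saturated chain carbon, two bonds along the chain from a nitrogen on an aromatic ring. Going by the values given here, no measured pair shows this particular change, so nothing directly tells its effect. Given how close compound 2 and compound 3 stand despite their very different chains, no step beyond the scatter in this assay is expected for this change. Compound 4 is therefore estimated at 250 ug/mL, within 80 ug/mL to 600 ug/mL, which means an expected step of a 1.3-fold lower number from compound 2 to compound 4 (0.10 log units; within the scatter).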

Compound 4, half-maximal cytotoxic concentration: 39.9 ug/mL
The estimate for compound 4 lay 6.3-fold (0.80 log units) above the measured number; measured number below the stated range.
By their numbers in this assay, from the lowest: compound 1; then compound 4; then compounds 2 and 3 (each within the scatter of the next).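

In this assay the entry of 1H-1,2,4-triazol-1-yl in place of ethyl, on a saturated chain carbon two bonds along the chain from a nitrogen on an aromatic ring, gives a 7.9-fold lower number from compound 2 to compound 4 (0.90 log units; beyond the scatter) and so points to higher toxicity in this test. Compounds 2 and 3 carry very different chains on that nitrogen and still stand within the scatter of each other, so on their own they suggested that this read-out pays little attention to what the chain holds; the new step shows that one change in this place can move the number well beyond the scatter. Nothing shown here accounts for that step, which stands as an observation without an explanation.

As far as these compounds go, it remains open whether the step belongs to the 1H-1,2,4-triazol-1-yl group itself or would also come with another group in the same place, such as a phenyl ring, an imidazole ring or a tertiary amine. From the compounds shown here alone, it is equally open whether a longer chain carrying the same 1H-1,2,4-triazol-1-yl group would keep the number as low as in compound 4.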